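Removing chlorine from a quinone core: expected effect on cytotoxicity

The source may hold more compounds than are shown below. What is called first, only, known or untested is meant among the compounds shown, and "the series" means these compounds.

Measured so far:
compound 1, `Cc1cc(Cl)c2c(c1O)C(=O)C=CC2=O`, 10000 nM
compound 2, `COc1cc(C)cc2c1C(=O)C=CC2=O`, 15300 nM
compound 3, `COc1cc(C)c(Cl)c2c1C(=O)C=CC2=O`, 20600 nM

In a functional assay on MCF7 cells (Homo sapiens) for cytotoxicity, read by XTT assay, with a stated time of 24 h (on this read-out lower numbers stand for stronger inhibition and higher numbers for weaker inhibition), compound 1 gives 10000 nM. Compound 2 and compound 3 share a core whose difference from that of compound 1 is not broken down here. Between them, one change has been measured: hydrogen in place of chloro on an aromatic carbon, which gave a 1.3-fold lower number from compound 3 to compound 2 (0.13 log units; within the scatter).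

Compound 4, `Cc1ccc2c(c1O)C(=O)C=CC2=O`, is not yet measured. It arises from compound 1 by the same kind of change, (hydrogen in place of chloro on an aromatic carbon), though the surroundings differ: in compound 3 the carbon that loses chlorine is ortho to a methyl group and para to a methoxy group, while in compound 1 it is meta to a methyl group and para to a hydroxy group. Because the measured step of a 1.3-fold lower number from compound 3 to compound 2 (0.13 log units; within the scatter) stayed within the scatter, compound 4 is expected to give roughly the same number as compound 1, a step of a 1.2-fold lower number from compound 1 to compound 4 (0.07 log units; within the scatter), and so an estimated 8500 nM with a plausible range from 3000 nM to 25000 nM.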

Compound 4, half-maximal inhibitory concentration: 15300 nM
Compound 4: middle estimate off by 1.8-fold (0.26 log units), on the low side, and the stated range covers the measured number.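

In this assay, hydrogen in place of chloro on the core of compound 1 gives a 1.5-fold higher number from compound 1 to compound 4 (0.18 log units; within the scatter), so the number stays within the usual scatter. Set beside the earlier step on the other core, this step does not stand apart: the same change on two cores in this assay, a 1.3-fold lower number (0.13 log units; within the scatter) from compound 3 to compound 2 and a 1.5-fold higher number (0.18 log units; within the scatter) from compound 1 to compound 4, 2.1-fold (0.31 log units) apart, within the scatter of two such steps The change therefore leaves the number about where it was on both cores, but steps this small cannot show whether the two cores truly respond alike or whether a real effect lies hidden in the scatter.

The compounds shown carry only chloro or hydrogen on this carbon. From the compounds shown here alone, what an amine, a carboxylic acid or a longer chain would do there remains open.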